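A methylpyrazole in place of the isothiazole ring

The compounds below may be only part of what the source reports. "The series", "measured", "known", "first", "only" and "open" are said of these compounds alone.

Compounds 1 to 3 share one core and differ only in the five-membered ring attached to it. In a functional assay for activation of Alpha-1D adrenergic receptor (Homo sapiens), read by calcium flux (on this read-out lower numbers stand for an effect already at smaller amounts and higher numbers for an effect only at larger amounts of compound), compound 2 `c1c[nH]c(-c2ccccc2OCC2=NCCN2)c1` gives 6.31 nM, and compound 3 `c1ccc(-c2ccns2)c(OCC2=NCCN2)c1` gives 25.1 nM; the step of a 4.0-fold higher number from compound 2 to compound 3 (0.60 log units; beyond the scatter) is modest but beyond the scatter. Compound 1 `c1coc(-c2ccccc2OCC2=NCCN2)c1` gives only a limit, < 100000 nM, so its steps to the others cannot be read (the limit of < 100000 nM in this assay, at which 1 of the 3 values shown sits). Compound 3 thus shows the higher of the two readable numbers. Compound 4 `Cn1nccc1-c1ccccc1OCC1=NCCN1` differs from compound 3 by 1-methyl-1H-pyrazol-5-yl in place of 1,2-thiazol-5-yl on an aromatic carbon. Going by the values given here, no measured step involves this new ring; the only readable step, a 4.0-fold higher number from compound 2 to compound 3 (0.60 log units; beyond the scatter), also swapped the ring and gave a modest shift. A shift of similar modest size is therefore expected, and compound 4 is estimated at 30 nM, between 8 nM and 120 nM, meaning a 1.2-fold higher number from compound 3 to compound 4 (0.08 log units; within the scatter).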

Compound 4, half-maximal effective concentration: < 100000 nM
Compound 4 gave a limit, no number; the forecaster's own chance of this, stated with the estimate: 5%; the middle value does not contradict the limit.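

Compound 4 gives only a limit in this assay, < 100000 nM, so none of its steps to compounds 1, 2 and 3 can be read. Going by these compounds, how far compound 4 lies from compound 2 or compound 3 stays open.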